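This account rests on a few compounds, and the source may have more. Where it says the series, first, only, none or still open, it means among the compounds named here.

Measured compounds:
- compound 1, `Cc1cccc(Cn2c(CN3CCN(C(=O)c4cccs4)CC3)nc3ccccc32)c1`: 60.8%
- compound 2, `CC(C)=CCn1c(CN2CCN(C(=O)C3CC3)CC2)nc2ccccc21`: 74.3%

Of the compounds shown here, two carrying the shared core have so far been tested in an assay on isolated protein for inhibition of aldehyde dehydrogenase 1A1 (Homo sapiens), read by spectrophotometry, tested at 10 uM; a lower number here means less inhibition, a higher number more inhibition at the concentration tested (going by the name of the read-out). Compound 1 gives 60.8%, which is the lower of the two numbers; compound 2 gives 74.3%, a reading higher than that of compound 1 by a margin beyond the usual scatter of repeated measurements. Among the measured compounds shown here, the two measured compounds differ from each other in more than one place, so no single step between them can be read off, and nothing measured so far speaks directly to the change now in question.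

Compound 3 `Cc1cccc(Cn2c(CN3CCN(C(=O)c4ccc(C#N)cc4)CC3)nc3ccccc32)c1` is the next compound to be measured. It differs from compound 1 in one place only:

4-cyanophenyl in place of thiophen-2-yl on a carbonyl carbon

For the measured compounds named here, with no measured step of this kind to lean on, the account rests on the value of compound 1 alone. The expected step of a number 0.8 percentage points lower from compound 1 to compound 3 (within the scatter) is estimated to be small, without a clear direction, and quite possibly within the scatter. Compound 3 is therefore expected to give about 60% in this assay, with a range from 35% to 82%.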

Compound 3, a percentage reported as inhibition, at one concentration (the size of the read-out at that concentration, not a potency): 20.8%
Estimate against measurement, compound 3: 39.2 percentage points above; the whole stated range lies above it.
By their numbers in this assay, from the lowest: compound 3; then compound 1; then compound 2.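

In this assay, the group on the carbonyl carbon proves to matter: with the rest of compound 1 held fixed, 4-cyanophenyl in place of thiophen-2-yl gives a number 40 percentage points lower from compound 1 to compound 3 (beyond the scatter), a large step. Among the compounds shown here, the two earlier compounds differed in more than one place, so they could not show this; this is the first reading of a change at this position alone, and it shows that the position is not indifferent to which aromatic ring it carries. Nothing available explains the fall in the reading.

This single step swaps a five-membered ring holding sulfur for a six-membered ring of carbon only and adds a nitrile at the same time, so the compounds shown do not separate these changes; an unsubstituted phenyl or a furan-2-yl on the same carbonyl carbon would speak to which of them carries the step. As far as these compounds go, it also remains open whether a 4-cyanophenyl would have the same effect with the 3-methylbut-2-enyl group of compound 2 on the shared core, or whether a carboxylic acid in place of the nitrile would behave alike.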